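Aryl exchange on the saturated ring carbon: compound 3 to compound 4

This account rests on a few compounds, and the source may have more. Where it says the series, first, only, none or still open, it means among the compounds named here.

compound 1 `CNC(=O)c1cc(Oc2ccc(C3=NNC(c4cc(OC)c(OC)c(OC)c4)C3)cc2)ccn1`: 37100 nM
compound 2 `CNC(=O)c1cc(Oc2ccc(C3=NNC(c4ccc(C#N)cc4)C3)cc2)ccn1`: 17400 nM
compound 3 `CNC(=O)c1cc(Oc2ccc(C3=NNC(c4ccc(F)cc4Cl)C3)cc2)ccn1`: 13700 nM

In a functional assay on A549 cells (Homo sapiens) for cytotoxicity, read by MTT assay, with a stated time of 72 h (on this read-out higher numbers stand for weaker inhibition and lower numbers for stronger inhibition), compound 3 gives 13700 nM and compound 2 gives 17400 nM, two values within the scatter of each other. Compound 1 gives 37100 nM, a higher number beyond the scatter of compound 3.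

Compound 4 `CNC(=O)c1cc(Oc2ccc(C3=NNC(c4ccc(OC)cc4)C3)cc2)ccn1` carries 4-methoxyphenyl in place of 2-chloro-4-fluorophenyl on a saturated ring carbon.

Going by the values given here, the one measured step at this place is a 1.3-fold lower number from compound 2 to compound 3 (0.10 log units; within the scatter), which stays within the scatter. Among the compounds with values here, compound 1, the only measured compound with methoxy groups, gives 37100 nM and so leaves some room for a higher number. Only a small upward shift is therefore expected in this assay, with no clear move beyond the scatter.

The expected change is a 1.5-fold higher number from compound 3 to compound 4 (0.16 log units; within the scatter).

For compound 4 the estimated value is 20000 nM, with an expected range of 10000 nM to 40000 nM.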

Compound 4, half-maximal inhibitory concentration: 13100 nM
For compound 4 the middle estimate is 1.5-fold (0.18 log units) above the measured one; measured number inside the range.
By their numbers in this assay, from the lowest: compounds 4, 3 and 2 (each within the scatter of the next); then compound 1.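

In this assay, the exchange of 2-chloro-4-fluorophenyl for 4-methoxyphenyl on the saturated ring carbon gives a 1.0-fold lower number from compound 3 to compound 4 (0.02 log units; within the scatter), and methoxy in place of cyano on an aromatic carbon gives a 1.3-fold lower number from compound 2 to compound 4 (0.12 log units; within the scatter). Across compounds 2, 3 and 4, this position therefore shows no separation among the nitrile-bearing, halogen-bearing and methoxy-bearing aryl groups. A methoxy group alone also does not go with the higher number seen for the trimethoxy-substituted aryl group: compound 4 gives 13100 nM, whereas compound 1 gives 37100 nM.

No supporting measurement is available to explain these results. From the compounds shown here alone, it remains open whether an amine or a carboxylic acid on this aryl group, or a cyclohexyl group in its place, would move the number beyond the scatter.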